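From 4-fluorophenyl to 4-methylphenyl: a small step expected

The source may hold more compounds than are shown below. What is called first, only, known or untested is meant among the compounds shown, and "the series" means these compounds.

Compound 1 `Cc1ccc(OCC(=O)NNC(=O)c2cc3ccccc3oc2=O)c(C(=O)c2cccc(Cl)c2)c1`: 67400 nM
Compound 2 `Cc1ccc(OCC(=O)NNC(=O)c2cc3ccccc3oc2=O)c(C(=O)c2ccc(F)cc2)c1`: 45700 nM

Both compounds were tested in a functional assay on DLA cells (Mus musculus) for cytotoxicity, read by LDH release, with a stated time of 48 h; on this read-out lower numbers stand for stronger inhibition and higher numbers for weaker inhibition. For the measured compounds named here, compound 2, at 45700 nM, stands within the scatter of compound 1, the only other compound measured, so the two cannot be ranked.

Compound 3 `Cc1ccc(C(=O)c2cc(C)ccc2OCC(=O)NNC(=O)c2cc3ccccc3oc2=O)cc1` keeps the shared core and alters one group: methyl in place of fluoro on an aromatic carbon. This places methyl in place of fluoro on an aromatic carbon, para to a large group, and so turns 4-fluorophenyl into 4-methylphenyl.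

Going by the values given here, one measured step bears on this change: a 1.5-fold lower number from compound 1 to compound 2 (0.17 log units; within the scatter). It also altered only the aryl group on the carbonyl carbon, and it stayed within the scatter. Among the compounds with values here, no measured compound carries the 4-methylphenyl group, so this single step is the only guide. No shift beyond the scatter is therefore expected in this assay, and neither direction is favoured.

The estimate amounts to an expected step of a 1.1-fold higher number from compound 2 to compound 3 (0.04 log units; within the scatter). For compound 3 the expected value is 50000 nM, with an estimated range from 25000 nM to 100000 nM.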

Compound 3, half-maximal inhibitory concentration: 87200 nM
Compound 3: the middle estimate sits 1.7-fold (0.24 log units) below what was measured, within the range that was stated.
By their numbers in this assay, from the lowest: compounds 2, 1 and 3 (each within the scatter of the next).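

In this assay, exchanging fluoro for methyl on an aromatic carbon, para to a large group, gives a 1.9-fold higher number from compound 2 to compound 3 (0.28 log units; within the scatter), so this position now has a second measured substituent, and the exchange of one heavy atom for another does not separate the two compounds. Placing 4-methylphenyl in place of 3-chlorophenyl on the carbonyl carbon gives a 1.3-fold higher number from compound 1 to compound 3 (0.11 log units; within the scatter), so all three aryl groups compared at this carbon lie within the scatter of one another and none can be ranked above the others. No measurement shown here offers an explanation for this result.

The compounds shown leave open whether any group at this position can move the number beyond the scatter, for example an amine, a carboxylic acid or a longer chain in place of the methyl of compound 3. They also leave open whether a change elsewhere on the shared core, away from this aryl group, would separate compounds in a way these three do not.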